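Fluoro for methyl on the aryl amide: compound 4

This account rests on a few compounds, and the source may have more. Where it says the series, first, only, none or still open, it means among the compounds named here.

Compound 1 `Cc1ccc(N2C(=O)COc3ccc(-c4cnc5ccccc5c4)cc32)cc1` and compound 2 `O=C1COc2ccc(-c3cnc4ccccc4c3)cc2N1c1ccc(F)cc1` share one core and differ only by fluoro in place of methyl on an aromatic carbon. In a functional assay on A549 cells (Homo sapiens) for antiproliferative activity, read by MTT assay, with a stated time of 72 h (on this read-out lower numbers stand for stronger inhibition and higher numbers for weaker inhibition), compound 1 gives > 40000 nM, which is a limit of the assay and not a number. In this assay compound 2 gives > 40000 nM, again a limit. The step that the two limits leave unreadable from compound 1 to compound 2 is therefore of unreadable size; all that can be said is that both compounds sit at the limit of > 40000 nM in this assay, at which 3 of the 3 values shown sit.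

Compound 3 `Cc1ccc(N2C(=O)COc3ccc(-c4cccc(NS(=O)(=O)c5ccc(F)cc5)c4)cc32)cc1` has a different core; the difference between the core of compound 3 and the core of compound 1 is not broken down here. In this assay compound 3 gives > 40000 nM, a limit of the assay. Compound 4 `O=C1COc2ccc(-c3cccc(NS(=O)(=O)c4ccc(F)cc4)c3)cc2N1c1ccc(F)cc1` is not yet measured and differs from compound 3 by fluoro in place of methyl on an aromatic carbon. This is the same change as that from compound 1 to compound 2, at a place described in the same words, and it occurs in two compound pairs among those shown.

Within the data shown here, the only measured instance of this change left both partners at the limit, and compound 3 itself sits at that limit, so no movement into the readable range is expected. The expected step in this assay is a step that the limit leaves unreadable from compound 3 to compound 4, resting on compound 3 giving > 40000 nM and on the step that the two limits leave unreadable from compound 1 to compound 2. For compound 4 the estimate in this assay is 60000 nM, most probably reported only as a limit, in the range 25000 nM to 200000 nM.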

Compound 4, half-maximal inhibitory concentration: > 40000 nM
Compound 4 gave a limit, no number; the forecaster's own chance of this, stated with the estimate: 85%; the middle value is on the limit's open side.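

In this assay no step can be read from compound 3 to compound 4, since both compounds stay at a limit of the assay and give no number: the limit of > 40000 nM in this assay, at which 4 of the 4 values shown sit.

The compounds shown leave open whether the change from 4-methylphenyl to 4-fluorophenyl alters antiproliferative activity at all, and where any of the four compounds would fall on a readable scale.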